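A few compounds are considered here, and "the series" means these few. Any claim that something is new, unique, unknown or untested is made for them only; others in the source may bear on it.

Compound 2 has the structure `COc1cccc(-c2nc(N)c3nc(-c4ccccc4)sc3n2)c1`. In a functional assay on CHO cells for antagonist activity at adenosine receptor A2b (Homo sapiens), read by cAMP accumulation, with a stated time of 10 min (a higher number here means a weaker inhibitor, a lower number a stronger inhibitor), compound 2 gives > 30000 nM, which is a limit of the measurement rather than a number. Its closest measured relative is compound 1, `Nc1nc(-c2ccccc2)nc2sc(-c3ccccc3)nc12`, which carries a hydrogen where compound 2 carries a methoxy group. In this assay compound 1 gives > 30000 nM, again a limit. The step that the two limits leave unreadable from compound 1 to compound 2 therefore cannot be read, because of the limit of > 30000 nM in this assay, at which 2 of the 2 values shown sit. The next compound, compound 3, has the structure `Nc1nc(-c2ccco2)nc2sc(-c3ccccc3)nc12` and differs from compound 2 by furan-2-yl in place of 3-methoxyphenyl on an aromatic carbon. Among the measured compounds shown here, the only measured step concerns a different group and is itself unreadable, so it offers no guidance on the size or direction of the change to expect in this assay here. For compound 3 the expectation is a value near the limit, estimated at 20000 nM with a range from 3000 nM to 60000 nM. The expected step is then an at least 1.5-fold lower number from compound 2 to compound 3 (0.17 log units; that floor lies within the scatter).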

Compound 3, half-maximal inhibitory concentration: > 30000 nM
Compound 3: only a limit was reported; the forecaster's own chance of this, stated with the estimate: 55%; middle value at least 1.5-fold (0.17 log units) from the limit.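

Compound 3 gives > 30000 nM in this assay, which is a limit, so its steps from compound 1 and compound 2 cannot be read: the limit of > 30000 nM in this assay, at which 3 of the 3 values shown sit.

The compounds shown leave open whether compound 1, compound 2 and compound 3 differ at all as inhibitors, and which change to the shared core would give a readable number.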